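Trading acetamido for tert-butyl on the shared core

The compounds below may be only part of what the source reports. "The series", "measured", "known", "first", "only" and "open" are said of these compounds alone.

Among the compounds with values here, compound 2 `CC(=O)Nc1ccc(-n2c(-c3cccnc3N)nc3cccnc32)cc1` gives 1300 nM in an in vitro assay on Sf9 cells for inhibition of RAC-alpha serine/threonine-protein kinase (Homo sapiens), read by AlphaScreen, with a stated time of 20 min (a higher number here means a weaker inhibitor, a lower number a stronger inhibitor), and stands at the top of the two numbers measured so far, though within the scatter of its one neighbour. That neighbour, compound 1 `Nc1ccc(-n2c(-c3cccnc3N)nc3cccnc32)cc1`, gives 740 nM in this assay, and the step of a 1.8-fold higher number from compound 1 to compound 2 (0.24 log units; within the scatter) is within the scatter. Compound 3 `CC(C)(C)c1ccc(-n2c(-c3cccnc3N)nc3cccnc32)cc1` has not been measured. It differs from compound 2 by tert-butyl in place of acetamido on an aromatic carbon. Within the data shown here, no measured step exchanges acetamido for tert-butyl; the only step known concerns a different exchange and did not leave the scatter. The measured compounds therefore give no ground for a sizeable step in either direction in this assay, and the expected step of a 1.2-fold higher number from compound 2 to compound 3 (0.06 log units; within the scatter) is small. Compound 3 is estimated at 1500 nM in this assay, with a range from 500 nM to 4500 nM.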

Compound 3, half-maximal inhibitory concentration: 3900 nM
For compound 3 the middle estimate is 2.6-fold (0.41 log units) below the measured one, within the range that was stated.
By their numbers in this assay, from the lowest: compounds 1 and 2 (each within the scatter of the next); then compound 3.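

In this assay, this place on the aromatic ring no longer looks indifferent to its substituent: tert-butyl in place of acetamido gives a 3.0-fold higher number from compound 2 to compound 3 (0.48 log units; beyond the scatter), and tert-butyl in place of amino gives a 5.3-fold higher number from compound 1 to compound 3 (0.72 log units; beyond the scatter). Within the data shown here, these are the first steps here to leave the scatter, and they make compound 3 the weakest of the three, whereas amino and acetamido remain within the scatter of each other. The acetamido exchange keeps the heavy-atom count unchanged, but nothing given here bears on why the number rises.

The compounds shown leave open whether the rise follows from losing the hydrogen-bond donor and acceptor of acetamido or from the tert-butyl group's all-carbon branched form. An isopropyl group, a methoxy group or a carboxylic acid at this place could begin to separate these readings.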